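Nitro to chloro on the benzoyl arm of compound 2

A few compounds are considered here, and "the series" means these few. Any claim that something is new, unique, unknown or untested is made for them only; others in the source may bear on it.

Measured so far:
compound 1, `CCOC(=O)/C(=C/c1c[nH]c2ccccc12)C(=O)c1ccc([N+](=O)[O-])cc1`: 100000 nM
compound 2, `CCOC(=O)/C(=C/c1c(-c2ccccc2)[nH]c2ccccc12)C(=O)c1ccc([N+](=O)[O-])cc1`: 1500 nM

In a functional assay on MT4 cells (Homo sapiens) for antiproliferative activity, read by MTT assay, with a stated time of 96 h (on this read-out lower numbers stand for an effect already at smaller amounts and higher numbers for an effect only at larger amounts of compound), compound 2 holds the lowest number of the two. Going by the values given here, the only measured step, a 67-fold lower number from compound 1 to compound 2 (1.82 log units; beyond the scatter), concerns phenyl in place of hydrogen and does not touch the group changed here. Compound 3, `CCOC(=O)/C(=C/c1c(-c2ccccc2)[nH]c2ccccc12)C(=O)c1ccc(Cl)cc1`, differs from compound 2 by chloro in place of nitro on an aromatic carbon. Among the compounds with values here, no measured step bears on this change, so the size and direction of the step are open. Compound 3 is expected to lie near compound 2, estimated at 2500 nM (range 600 nM to 10000 nM), a step of a 1.7-fold higher number from compound 2 to compound 3 (0.22 log units; within the scatter).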

Compound 3, half-maximal effective concentration: 9000 nM
Estimate against measurement, compound 3: 3.6-fold (0.56 log units) below; low and high end bracket the measured number.
By their numbers in this assay, from the lowest: compound 2; then compound 3; then compound 1.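

In this assay, chloro in place of nitro on the aromatic carbon gives a 6.0-fold higher number from compound 2 to compound 3 (0.78 log units; beyond the scatter). The benzoyl arm is therefore not a silent position, and of the two groups compared here on this core, nitro goes with the lower number. No data at hand account for this step.

Going by these compounds, an amine or a carboxylic acid at this position remains open. So does whether chloro in place of nitro would give a step of similar size and direction on the core of compound 1.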